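A few compounds are considered here, and "the series" means these few. Any claim that something is new, unique, unknown or untested is made for them only; others in the source may bear on it.

For the measured compounds named here, in a functional assay for agonist activity at growth hormone secretagogue receptor type 1 (Homo sapiens), read by FLIPR (on this read-out higher numbers stand for larger maximal responses and lower numbers for smaller maximal responses), compound 2, whose structure is `COc1cccc(-c2ccc(S(=O)(=O)Nc3cc(N4C[C@@H](C)N[C@@H](C)C4)ccc3OC)cc2)c1`, gives 1, the higher of the two values so far. Compound 1, with the structure `C[C@@H]1CN(c2cccc(NS(=O)(=O)c3ccc(-c4ccccn4)s3)c2)C[C@H](C)N1`, gives 0.8 in this assay, a value that falls beyond the usual scatter below that of compound 2; no single change connects these two compounds, so the two values are simply set side by side. Compound 3, with the structure `COc1ccc(N2C[C@@H](C)N[C@@H](C)C2)cc1NS(=O)(=O)c1ccc(-c2ccc(C)o2)cc1`, has not yet been measured in this assay. It differs from compound 2 in one place, (5-methylfuran-2-yl in place of 3-methoxyphenyl on an aromatic carbon). Going by the values given here, with no measured step to go by, compound 3 is expected to stay near compound 2, with a change of a number 0.10 lower from compound 2 to compound 3 (within the scatter) in this assay that would lie within the scatter or only just beyond it. The estimate for compound 3 in this assay is therefore 0.9, within a range from 0.7 to 1.05.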

Compound 3, intrinsic activity: the largest response reached, as a fraction of the reference agonist's: 1
Compound 3: the middle estimate sits 0.10 below what was measured; measured number inside the range.
By their numbers in this assay, from the lowest: compound 1; then compounds 2 and 3 (each within the scatter of the next).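

In this assay the change at this position, on an aromatic carbon para to a large group, gives no change at the digits printed from compound 2 to compound 3 (within the scatter) as 5-methylfuran-2-yl replaces 3-methoxyphenyl. For the compounds shown here, this is the first single-place comparison, and it shows that the maximal response holds when a five-membered aromatic ring with 1 hetero atom and 6 heavy atoms stands where a six-membered aromatic ring of carbon only with 8 heavy atoms stood. No supporting evidence bears on why the response holds across this change. The compounds shown leave open whether a group without an aromatic ring at this position, such as an amine, a carboxylic acid or a longer alkyl chain, would keep the response. They also leave open whether the same change would give a similar result on the core of compound 1.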